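Working notes: 3-chlorophenyl to 2-(4-chlorophenyl)ethenyl

The source may report more compounds than this note shows. Statements on the series, on what has been measured and on what is new or still open speak of the compounds shown alone.

Compound 1 `COc1ccc(/C=C/C(=O)Nc2cc(Sc3ncn[nH]3)c(O)c3ccccc23)cc1OC` reads > 100000 nM in a functional assay on PC-3 cells (Homo sapiens) for antiproliferative activity, read by MTT assay, with a stated time of 48 h (on this read-out lower numbers stand for stronger inhibition and higher numbers for weaker inhibition), and this is a limit of the assay, not a number. For the measured compounds named here, compound 2 `O=C(Nc1cc(Sc2ncn[nH]2)c(O)c2ccccc12)c1cccc(Cl)c1` gives 85600 nM in this assay, the only actual number so far. Compound 3 `O=C(/C=C/c1ccc(Cl)cc1)Nc1cc(Sc2ncn[nH]2)c(O)c2ccccc12` has 2-(4-chlorophenyl)ethenyl in place of 3-chlorophenyl on a carbonyl carbon. Going by the values given here, no measured step bears on this change, so no shift beyond the scatter is expected, and the estimated step is a 1.2-fold lower number from compound 2 to compound 3 (0.09 log units; within the scatter). For compound 3 the estimate in this assay is 70000 nM, with an expected range of 25000 nM to 100000 nM.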

Compound 3, half-maximal inhibitory concentration: > 100000 nM
Compound 3 was reported as a limit; the forecaster's own chance of this, stated with the estimate: 40%; middle value at least 1.4-fold (0.15 log units) away from the limit.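

Putting 2-(4-chlorophenyl)ethenyl in place of 3-chlorophenyl on the carbonyl carbon gives, in this assay, an at least 1.1-fold higher number from compound 2 to compound 3 (0.06 log units; that floor lies within the scatter), so this change shows no gain over compound 2. Compound 3 gives > 100000 nM, which is a limit of the assay and not a number. The series now rests largely on that limit: the limit of > 100000 nM in this assay, at which 2 of the 3 values shown sit.

Going by these compounds, the step between compound 1 and compound 3 cannot be read, and how far compound 3 lies past the limit stays open. Also open, on these data alone, is whether an amine or a carboxylic acid in place of 3-chlorophenyl on the carbonyl carbon would give a stronger reading.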